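The compounds below may be only part of what the source reports. "The series", "measured", "known", "first", "only" and "open" are said of these compounds alone.

Compound 2 `COc1cc(-c2nn(-c3cccc(NC(=O)Nc4ccc(Cl)c(C(F)(F)F)c4)c3)cc2-c2ccncc2)ccc1Cl` carries a methoxy on the aryl ring bearing chlorine and a chloro-trifluoromethyl-substituted urea; in a functional assay on HOP-92 cells (Homo sapiens) for inhibition, read by sulforhodamine B assay, with a stated time of 48 h (a higher number here means a weaker inhibitor, a lower number a stronger inhibitor), compound 2 gives 500 nM. Compound 1 `O=C(Nc1cccc(-n2cc(-c3ccncc3)c(-c3ccc(Cl)c(O)c3)n2)c1)Nc1ccc(Cl)c(Cl)c1` differs in both the phenol and the urea aryl; in this assay compound 1 gives 680 nM. Compound 2 has the lowest of the two numbers, but the gap to compound 1 lies within the usual scatter, so no order between them is claimed.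

Compound 3 `O=C(Nc1cccc(-n2cc(-c3ccncc3)c(-c3ccc(Cl)c(O)c3)n2)c1)Nc1ccc(Cl)c(C(F)(F)F)c1` has not been measured. It differs from compound 2 by hydrogen in place of methyl on an oxygen on an aromatic ring. No measured pair in the series isolates this change, so the expectation rests on the two numbers shown, both of which sit close together despite different substitution. A step within the scatter, in no set direction, is expected, a 1.1-fold higher number from compound 2 to compound 3 (0.05 log units; within the scatter). Compound 3 is expected to give about 560 nM, likely between 250 nM and 1250 nM.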

Compound 3, half-maximal inhibitory concentration: 380 nM
The estimate for compound 3 lay 1.5-fold (0.17 log units) above the measured number; low and high end bracket the measured number.
By their numbers in this assay, from the lowest: compounds 3, 2 and 1 (each within the scatter of the next).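

Methoxy to hydroxy on the 4-chloro-3-methoxyphenyl ring can now be read on its own: this assay gives a 1.3-fold lower number from compound 2 to compound 3 (0.12 log units; within the scatter) for this change, so neither group at this oxygen separates from the other beyond the scatter. Trifluoromethyl in place of chloro on an aromatic carbon can also be read on its own, as a 1.8-fold lower number from compound 1 to compound 3 (0.25 log units; within the scatter) and so also without a step beyond the scatter, and compound 3 thereby links the two earlier compounds through single changes. Nothing available offers an explanation for the size of either step.

From the compounds shown here alone, an amine in place of the hydroxy, or an ethoxy or longer alkoxy chain on the same oxygen, remains open. Going by these compounds, whether either change would read the same way in other cell lines also remains open.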